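A few compounds are considered here, and "the series" means these few. Any claim that something is new, unique, unknown or untested is made for them only; others in the source may bear on it.

Three hydrazides of a shared core have been tested in a functional assay on PC-3 cells (Homo sapiens) for cytotoxicity; on this read-out lower numbers stand for stronger inhibition and higher numbers for weaker inhibition. Compound 1 `O=C(N/N=C\c1cn(Cc2ccc(Cl)cc2)c2ccc(Br)cc12)c1c[nH]c2ccccc12` gives 12400 nM, compound 2 `O=C(N/N=C\c1cn(Cc2ccc(Cl)cc2)c2cc(F)ccc12)c1c[nH]c2ccccc12` gives 19500 nM, and compound 3 `COc1ccc(Cn2cc(/C=N\NC(=O)c3cn(C)c4ccccc34)c3ccc(F)cc32)cc1` gives 12800 nM in this assay. Among these three numbers, that of compound 3 is the second highest; compound 1 sits nearest to it and compound 2 furthest, yet both gaps lie within the scatter, so the three compounds cannot be told apart on these data. Compound 4 `COc1ccc(Cn2cc(/C=N\NC(=O)c3c[nH]c4ccc(Br)cc34)c3ccc(F)cc32)cc1` has not yet been measured. It differs from compound 3 in one place: 5-bromo-1H-indol-3-yl in place of 1-methyl-1H-indol-3-yl on a carbonyl carbon. Among the compounds with values here, no measured pair isolates this change, so only a small shift is expected in this assay, with no direction firmly expected: a 1.3-fold lower number from compound 3 to compound 4 (0.11 log units; within the scatter) is the estimated step. Compound 4 is therefore expected to give about 10000 nM, within a range from 4000 nM to 25000 nM.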

Compound 4, half-maximal inhibitory concentration: 21800 nM
Compound 4: the middle estimate sits 2.2-fold (0.34 log units) below what was measured, and the stated range covers the measured number.
By their numbers in this assay, from the lowest: compounds 1, 3, 2 and 4 (each within the scatter of the next).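

In this assay, 5-bromo-1H-indol-3-yl in place of 1-methyl-1H-indol-3-yl on a carbonyl carbon gives a 1.7-fold higher number from compound 3 to compound 4 (0.23 log units; within the scatter), the first single-place step read at this position. This exchange of one indolyl group for another therefore leaves no change beyond the scatter. No measurement at hand bears on this result. As far as these compounds go, the bromine and the free ring hydrogen enter together, so their separate contributions remain open. Also open, from the compounds shown here alone, is whether an amine or a carboxylic acid on this carbonyl carbon would shift the number beyond the scatter.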